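The source may report more compounds than this note shows. Statements on the series, on what has been measured and on what is new or still open speak of the compounds shown alone.

Going by the values given here, in an ADME assay on MRC5 cells (Homo sapiens) for inhibition, with a stated time of 72 h (a lower number here means that less compound is needed, a higher number that more compound is needed for the effect), three compounds have numbers so far. Compound 1 `CO[C@H]1CC[C@H](NC(=O)c2n[nH]cc2NC(=O)c2cc3ccccn3n2)CC1` gives 1000 nM. Compound 3 `CO[C@H]1CC[C@H](NC(=O)c2n[nH]cc2NC(=O)c2c(C)nc3ccccn23)CC1` gives 34000 nM. Compound 2 `COc1cccc(OC)c1C(=O)Nc1c[nH]nc1C(=O)NCc1ccccc1` gives 50000 nM, the highest of the three numbers; next to it stands compound 3, whose number lies within the usual scatter of the assay, so these two cannot be told apart, while compound 1 lies far lower, well beyond the scatter. Compound 4 `COc1cccc(OC)c1C(=O)Nc1c[nH]nc1C(=O)NCC1CCCCC1` has not yet been measured. It differs from compound 2 in one place: cyclohexyl in place of phenyl on a saturated chain carbon bound to an amide-type nitrogen. Among the compounds with values here, no pair of measured compounds shows this exchange, so nothing measured tells how large its effect is, and the cyclohexyl group neither adds nor removes any hydrogen-bond donor or acceptor. The expected step is a 1.3-fold lower number from compound 2 to compound 4 (0.10 log units; within the scatter), that is, no change beyond the scatter. Compound 4 is therefore estimated to give about 40000 nM in this assay, with a likely range from 15000 nM to 100000 nM.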

Compound 4, half-maximal effective concentration: > 50000 nM
Compound 4 gave a limit, no number; the forecaster's own chance of this, stated with the estimate: 25%; middle value at least 1.2-fold (0.09 log units) from the limit.
By their numbers in this assay, from the lowest: compound 1; then compounds 3 and 2 (each within the scatter of the next).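

In this assay, the exchange of phenyl for cyclohexyl gives a number no lower from compound 2 to compound 4 (the limit leaves the size open). Going by these compounds alone, this is the first measured change at this place, on a saturated chain carbon bound to an amide-type nitrogen, and it shows that replacing the aromatic ring with a non-aromatic ring of the same heavy-atom count brings no lower number. The size of the step cannot be read because compound 4 gave only a limit: the limit of > 50000 nM in this assay, at which 1 of the 4 values shown sits.

Neither ring shows whether any group at this place can give a number lower than that of compound 2, 50000 nM. As far as these compounds go, what an amine or a carboxylic acid would do here stays open, as does the effect of a longer chain carrying the phenyl.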